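Swapping a pyridine for a pyrimidine on the amine

This account rests on a few compounds, and the source may have more. Where it says the series, first, only, none or still open, it means among the compounds named here.

Of the compounds shown here, three built on one shared core have been tested in a functional assay on HEK293 cells for antagonist activity at Orexin receptor type 2 (Homo sapiens), read by FLIPR and calcium flux; a lower number here means a less potent compound, a higher number a more potent compound, by a factor of ten per unit of this negative logarithm. Compound 1 `Cc1cnn(-c2ccc(C)nc2C(=O)N2CC3(CC3)C[C@H]2CNc2ccc(C(F)(F)F)cn2)c1` gives 8.3 in this assay. Compound 3 `Cc1nc(C(=O)N2CC3(CC3)C[C@H]2CNc2cc(C(F)(F)F)ccn2)c(-c2ccccc2)s1` gives 8.5 in this assay, the higher of the two numbers recorded, though the gap to compound 1 lies within the usual scatter, so the two cannot be told apart. Compound 2 `Cc1nc(C(=O)N2CCC3(CC3)C[C@H]2CNc2ccc(C(F)(F)F)cn2)c(-c2ccccc2)s1` returns < 5 in this assay, which is a limit rather than a number (the limit of < 5 in this assay, at which 1 of the 3 values shown sits).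

Compound 4 `Cc1nc(C(=O)N2CC3(CC3)C[C@H]2CNc2ncc(Cl)cn2)c(-c2ccccc2)s1` has not yet been measured. It differs from compound 3 in a single place: 5-chloropyrimidin-2-yl in place of 4-(trifluoromethyl)pyridin-2-yl on an amine nitrogen. Within the data shown here, no measured pair shows this exact exchange, so the expectation rests on compound 3 alone and on the modest size of the change. The expected step, a number 0.50 log units lower from compound 3 to compound 4 (beyond the scatter), is a slight loss that may well sit inside the scatter. Compound 4 is therefore expected to give about 8 in this assay, with a likely range from 7.2 to 8.7.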

Compound 4, negative logarithm of the antagonist equilibrium constant: 6.8
The estimate for compound 4 lay 1.20 log units above the measured number, and the stated range ends above it.
By their numbers in this assay, from the lowest: compound 4; then compounds 1 and 3 (each within the scatter of the next). At a limit, below all of these: compound 2.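

Exchanging 4-(trifluoromethyl)pyridin-2-yl for 5-chloropyrimidin-2-yl on the amine nitrogen gives a number 1.70 log units lower from compound 3 to compound 4 (beyond the scatter) in this assay, so this exchange is far from neutral. This is the only pair shown that differs at this position alone, and it shows that, on the core of compound 3, the aromatic group on the amine cannot be exchanged freely without a clear loss of potency. Nothing measured among these compounds accounts for that loss.

The exchange alters both the ring and its substituent at once, so the compounds shown cannot tell which of the two changes carries the loss. A 5-chloropyridin-2-yl or a 5-(trifluoromethyl)pyrimidin-2-yl group on the same amine nitrogen would pull these two changes apart.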